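A Carboxycyclohexyl Group Takes the Place of 3-Iodophenyl

The compounds below may be only part of what the source reports. "The series", "measured", "known", "first", "only" and "open" are said of these compounds alone.

In a functional assay on Hs 683 cells (Homo sapiens) for cytotoxicity, read by MTT assay (a lower number here means a stronger inhibitor, a higher number a weaker inhibitor), compound 1 (`Oc1ccc(CN(Cc2ccccc2)Cc2ccc(O)c3ncccc23)c2cccnc12`) gives 76 nM, compound 2 (`Oc1ccc(CN(Cc2ccccc2C(F)(F)F)Cc2ccc(O)c3ncccc23)c2cccnc12`) gives 64 nM and compound 3 (`Oc1ccc(CN(Cc2cccc(I)c2)Cc2ccc(O)c3ncccc23)c2cccnc12`) gives 479 nM, the highest number of the three. Compound 4 (`O=C(O)C1CCC(CN(Cc2ccc(O)c3ncccc23)Cc2ccc(O)c3ncccc23)CC1`) carries 4-carboxycyclohexyl in place of 3-iodophenyl on a saturated chain carbon bound to an amine nitrogen. Within the data shown here, no measured step introduces this group. The closest guides are a 6.3-fold higher number from compound 1 to compound 3 (0.80 log units; beyond the scatter) and a 7.5-fold higher number from compound 2 to compound 3 (0.87 log units; beyond the scatter), whereas a 1.2-fold lower number from compound 1 to compound 2 (0.07 log units; within the scatter) shows little movement. Those larger steps suggest that this position can shift the number by a modest amount, though the direction here remains uncertain. The expected change is a 2.1-fold higher number from compound 3 to compound 4 (0.32 log units; beyond the scatter). Compound 4 is estimated at 1000 nM, with an expected range of 200 nM to 5000 nM.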

Compound 4, half-maximal inhibitory concentration: 2860 nM
Beside the measured number, compound 4's estimate is 2.9-fold (0.46 log units) below it, and the stated range covers the measured number.
By their numbers in this assay, from the lowest: compounds 2 and 1 (each within the scatter of the next); then compound 3; then compound 4.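

In this assay, 4-carboxycyclohexyl on a saturated chain carbon bound to an amine nitrogen gives a 6.0-fold higher number from compound 3 to compound 4 (0.78 log units; beyond the scatter), with larger steps of a 38-fold higher number from compound 1 to compound 4 (1.58 log units; beyond the scatter) and a 45-fold higher number from compound 2 to compound 4 (1.65 log units; beyond the scatter). The earlier steps shown here changed only substituents on a phenyl ring, whereas this one replaces the aromatic ring with a non-aromatic ring carrying a carboxyl group, and it gives the highest number of the four. No evidence is available on why the number rises.

The ring and the carboxyl group change together, so the compounds shown leave open which one accounts for the step. A plain cyclohexyl group and a phenyl ring bearing a carboxylic acid would separate the two.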